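Swapping a Methoxyethyl Ester for a Cyclohexylmethyl Ester

The source may report more compounds than this note shows. Statements on the series, on what has been measured and on what is new or still open speak of the compounds shown alone.

Three compounds have been measured in an assay on isolated protein (strain albino) for antagonist activity at Voltage-dependent L-type calcium channel subunit alpha-1C (Cavia porcellus); a higher number here means a weaker inhibitor, a lower number a stronger inhibitor:
Compound 1 `COC(=O)C1=C(C)NC(C)=C(C(=O)OC(C)C)C1c1cnc(SC)n1Nc1ccccc1` gives 6.35 nM.
Compound 2 `CCOC(=O)C1=C(C)NC(C)=C(C(=O)OC(C)C)C1c1cnc(SC)n1Nc1ccccc1` gives 3.22 nM.
Compound 3 `COCCOC(=O)C1=C(C)NC(C)=C(C(=O)OC(C)C)C1c1cnc(SC)n1Nc1ccccc1` gives 53.4 nM.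

Compound 3 stands highest of the three in this assay: an 8.4-fold higher number from compound 1 to compound 3 (0.92 log units; beyond the scatter), and a 17-fold higher number from compound 2 to compound 3 (1.22 log units; beyond the scatter). Compound 4 `CSc1ncc(C2C(C(=O)OCC3CCCCC3)=C(C)NC(C)=C2C(=O)OC(C)C)n1Nc1ccccc1` differs from compound 3 in one place: cyclohexyl in place of methoxymethyl on a saturated chain carbon bound to an oxygen next to a carbonyl group. Among the measured compounds shown here, two measured steps bear on this. Introducing the methoxymethyl produced both increases just named, whereas the only step between plain carbon esters, a 2.0-fold lower number from compound 1 to compound 2 (0.29 log units; within the scatter), stayed within the scatter. Removing the methoxymethyl is therefore expected to bring the number back down toward compounds 1 and 2, with the ring adding little. Compound 4 is expected to give 5 nM, between 1.5 nM and 20 nM, which means an expected 11-fold lower number from compound 3 to compound 4 (1.03 log units; beyond the scatter).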

Compound 4, half-maximal inhibitory concentration: 56 nM
Compound 4: the middle estimate sits 11-fold (1.05 log units) below what was measured, outside the stated range (above it).
By their numbers in this assay, from the lowest: compounds 2 and 1 (each within the scatter of the next); then compounds 3 and 4 (each within the scatter of the next).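

In this assay, cyclohexyl and methoxymethyl on this carbon cannot be told apart, with a 1.0-fold higher number from compound 3 to compound 4 (0.02 log units; within the scatter). An oxygen in the added group is therefore not needed for the number to rise: the all-carbon cyclohexyl also stands well above the smaller esters, with an 8.8-fold higher number from compound 1 to compound 4 (0.95 log units; beyond the scatter) and a 17-fold higher number from compound 2 to compound 4 (1.24 log units; beyond the scatter).

On these data alone, whether a phenyl ring, a longer plain chain or an amine on this carbon would give a similarly high number remains open. Nothing measured here explains why these two different groups give such similar numbers.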